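Chloro in place of methoxy: what to expect

The compounds below may be only part of what the source reports. "The series", "measured", "known", "first", "only" and "open" are said of these compounds alone.

Measured so far:
compound 1 `Cc1ccc(C2CC(c3ccc(Cl)cc3)=NN2c2nc3ccc(S(N)(=O)=O)cc3s2)cc1` — a functional assay on the whole organism (strain Wistar) for inhibition, with Rattus norvegicus as the target, read by paw edema, with stated times of 1 h and 5 h, at a dose of 20 mg/kg by the oral route; on this read-out higher numbers stand for more inhibition at the one dose given (going by the name of the read-out) and lower numbers for less inhibition: 14%
compound 2 `COc1ccc(C2CC(c3ccc(Cl)cc3)=NN2c2nc3ccc(S(N)(=O)=O)cc3s2)cc1` — this assay: 67.7%

Compound 2 stands highest of the two numbers in this assay; its nearest neighbour is compound 1, and the step of a number 53.7 percentage points higher from compound 1 to compound 2 (beyond the scatter) lies beyond the scatter, so the single position varied here makes a large difference.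

Compound 3 `NS(=O)(=O)c1ccc2nc(N3N=C(c4ccc(Cl)cc4)CC3c3ccc(Cl)cc3)sc2c1` is the next compound. It differs from compound 2 by chloro in place of methoxy on an aromatic carbon.

Among the compounds with values here, no measured step covers this exact change. Within the data shown here, the only step available, a number 53.7 percentage points higher from compound 1 to compound 2 (beyond the scatter), concerns methyl against methoxy at the same aromatic carbon and shows that what sits there moves the read-out strongly. Chloro, like methyl, carries no hydrogen-bond acceptor, so the number for compound 3 is expected to fall back toward that of compound 1 rather than stay with compound 2, but the size of that fall is uncertain. The step is therefore estimated at a number 29.7 percentage points lower from compound 2 to compound 3 (beyond the scatter), a drop beyond the scatter.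

Compound 3 is expected to give 38% in this assay, within 12% to 68%.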

Compound 3, a percentage reported as inhibition, in the whole organism at one dose (the size of the read-out at that dose, not a potency): 14%
For compound 3 the middle estimate is 24 percentage points above the measured one; measured number inside the range.
By their numbers in this assay, from the lowest: compounds 1 and 3 (each within the scatter of the next); then compound 2.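

In this assay, the change from 4-methoxyphenyl to 4-chlorophenyl gives a number 53.7 percentage points lower from compound 2 to compound 3 (beyond the scatter), which shows that the high reading of compound 2 does not carry over to this second replacement of methoxy at this aromatic carbon. Chloro in place of methyl gives no change at the digits printed from compound 1 to compound 3 (within the scatter), so these two groups cannot be told apart on this read-out, and within this set of three only the methoxy compound stands apart, with steps beyond the scatter to both others. The data at hand offer no explanation of why methoxy alone gives the high reading at this position.

The three compounds leave open whether the high reading is specific to methoxy or would also appear with other groups at the same place, such as a hydroxyl, an amine or a longer ether chain like ethoxy. They also leave open whether the same change would have the same effect with a group other than the 4-chlorophenyl held constant elsewhere on the shared core.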